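Swapping the Amine Substituent on an Inactive Scaffold

The source may report more compounds than this note shows. Statements on the series, on what has been measured and on what is new or still open speak of the compounds shown alone.

Compound 1 `C[C@@H](Nc1c(C(=O)NCc2ccc(F)cc2)nc(Br)c2cccnc12)c1ccccc1` was tested in a functional assay on HCT-116 cells (Homo sapiens) for cytotoxicity, read by MTT assay, with a stated time of 72 h; a higher number here means a weaker inhibitor, a lower number a stronger inhibitor; compound 1 gives only a limit there, > 20000 nM, so its true potency is not fixed by a number. Compound 2 `COC(=O)c1nc(Br)c2cccnc2c1N[C@H]1CC[C@H](N)CC1` has no result in this assay, being recorded as "not determined" (no result reported). Compound 3 `O=C(NCc1ccc(F)cc1)c1nc(Br)c2cccnc2c1NCc1ccc(F)cc1` differs from compound 1 by 4-fluorobenzyl in place of 1-phenylethyl on a nitrogen on an aromatic ring. Among the compounds with values here, with compound 1 sitting at the limit of > 20000 nM in this assay, at which 1 of the 2 values shown sits, and no measured step to lean on, the expected step of a number no higher from compound 1 to compound 3 (the limit leaves the size open) is none beyond the scatter. Compound 3 is thus estimated at about 20000 nM, in a range from 6000 nM to 60000 nM.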

Compound 3, half-maximal inhibitory concentration: > 20000 nM
Compound 3: only a limit was reported; the forecaster's own chance of this, stated with the estimate: 70%; the middle value sits exactly at the limit.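

Within the data shown here, compound 1 and compound 3 both give only a limit in this assay, so no step between them can be read: the limit of > 20000 nM in this assay, at which 2 of the 3 values shown sit.

On these data alone, how strongly either compound acts, and whether 4-fluorobenzyl in place of 1-phenylethyl on a nitrogen on an aromatic ring changes that, stays open.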